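The source may report more compounds than this note shows. Statements on the series, on what has been measured and on what is new or still open speak of the compounds shown alone.

Measured so far:
compound 1, `Nc1scc(CN2CCN(c3cccc(F)c3)CC2)c1C(=O)c1ccc(Cl)cc1`: -82%
compound 2, `Nc1scc(CN2CCN(c3cccc(Cl)c3)CC2)c1C(=O)c1ccc(Cl)cc1`: -77%

Both numbers come from a functional assay on CHO cells with adenosine receptor A1 (Homo sapiens) as the target, read by cAMP accumulation and immunoassay, with a stated time of 6 min, tested at 10 uM; a higher number here means a weaker effect of the compound at the concentration tested, a lower number a stronger effect. Compound 2 and compound 1 lie close together: a number 5 percentage points higher from compound 1 to compound 2 (within the scatter), a gap within the usual scatter, so the two cannot be told apart on these numbers, and compound 2 is simply one of two nearly equal readings.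

Compound 3, `Nc1scc(CN2CCN(c3cc(Cl)ccc3Cl)CC2)c1C(=O)c1ccc(Cl)cc1`, differs from compound 2 by chloro in place of hydrogen on an aromatic carbon, so the 3-chlorophenyl of compound 2 becomes a 2,5-dichlorophenyl. Going by the values given here, the only measured step, from compound 1 to compound 2, exchanged one halogen for another and stayed within the scatter; no measured step adds a second chloro, so nothing bears directly on this change. With no sign of movement so far, the expected step is a number 2 percentage points higher from compound 2 to compound 3 (within the scatter), that is nothing beyond the scatter.

Compound 3 is therefore estimated at -75% in this assay, with a range from -95% to -50%.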

Compound 3, a percentage reported as activity, at one concentration (the size of the read-out at that concentration, not a potency): -62%
Estimate against measurement, compound 3: 13 percentage points below; measured number inside the range.
By their numbers in this assay, from the lowest: compounds 1 and 2 (each within the scatter of the next); then compound 3.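

Adding a second chloro on the aromatic ring, ortho to a large group and para to the existing chloro group, gives a number 15 percentage points higher from compound 2 to compound 3 (beyond the scatter) in this assay and so a weaker effect at the concentration tested, the first change here that lies beyond the scatter. The wider comparison points the same way, with a number 20 percentage points higher from compound 1 to compound 3 (beyond the scatter) when 2,5-dichlorophenyl replaces 3-fluorophenyl, so swapping one halogen for another left no readable difference, while this added chloro did. Nothing measured here accounts for this weakening.

As far as these compounds go, it remains open whether the change depends on this particular place or on chloro itself, which a methyl or methoxy group on the same carbon could help separate. Also open, from the compounds shown here alone, is how an amine or a carboxylic acid on this ring would read at the same concentration.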